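A few compounds are considered here, and "the series" means these few. Any claim that something is new, unique, unknown or untested is made for them only; others in the source may bear on it.

Of the compounds shown here, two have been measured in a functional assay on HOS cells (Homo sapiens) for antiproliferative activity, read by sulforhodamine B assay; on this read-out lower numbers stand for stronger inhibition of growth and higher numbers for weaker inhibition of growth. Compound 1, `c1ccc(COC[C@H]2OCC[C@@H](OCc3ccccc3)[C@@H]2OCc2ccccc2)cc1`, gives 22200 nM in this assay. For the measured compounds named here, compound 2, `CC(=O)O[C@@H]1[C@@H](OCc2ccccc2)[C@H](OCc2ccccc2)[C@@H](COCc2ccccc2)O[C@H]1C`, gives 8800 nM in this assay, the lower of the two numbers; the gap to compound 1 lies beyond the usual scatter of the measurement, so compound 2 stands as the stronger of the pair on the numbers so far.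

Compound 3, `CC[C@@H]1O[C@H](COCc2ccccc2)[C@@H](OCc2ccccc2)[C@H](OCc2ccccc2)[C@H]1OC(C)=O`, is not yet measured. It differs from compound 2 in a single place: methyl in place of hydrogen on a saturated chain carbon bound to a saturated ring carbon. Cut one bond further out, the same difference reads methyl to ethyl.

Going by the values given here, no step between measured compounds of this kind is available, so the expectation rests on the small size of the change alone. The step from compound 2 is expected to be small, in either direction or none beyond the scatter, with an estimated 1.1-fold lower number from compound 2 to compound 3 (0.04 log units; within the scatter). Compound 3 is therefore estimated at 8000 nM in this assay, with a range of 3500 nM to 18000 nM.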

Compound 3, concentration for 50% growth inhibition: > 50000 nM
Compound 3: no number, only a limit; the forecaster's own chance of this, stated with the estimate: 5%; middle value at least 6.2-fold (0.79 log units) away from the limit.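

At this position a single added carbon is not a silent change: methyl in place of hydrogen on a saturated chain carbon bound to a saturated ring carbon gives an at least 5.6-fold higher number from compound 2 to compound 3 (0.75 log units; beyond the scatter) in this assay. For the compounds shown here, compound 3 gives > 50000 nM, which is a limit of the assay and not a number, so the step has only a floor, set by: the limit of > 50000 nM in this assay, at which 1 of the 3 values shown sits. This is the only single-place step, so the sensitivity of growth inhibition to this place rests on one pair.

The compounds shown leave open how far the true value of compound 3 lies from the limit. They also leave open whether a propyl chain, a hydroxyl or an amine on this same carbon would behave like the ethyl group of compound 3 or like the methyl group of compound 2.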